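Swapping the sulfur-linked ring: what compound 4 may show

This account rests on a few compounds, and the source may have more. Where it says the series, first, only, none or still open, it means among the compounds named here.

Measured compounds:
compound 1, `Cc1nnc(SCC(=O)N/N=c2/scc(-c3ccc(F)cc3)n2-c2ccccc2)s1`, 37.4%
compound 2, `Cc1ccc(-c2cs/c(=N/NC(=O)CSc3nncn3C)n2-c2ccccc2)cc1`, 53.8%
compound 3, `Cc1ccc(-c2cs/c(=N/NC(=O)CSc3nnnn3C)n2-c2ccccc2)cc1`, 44.3%

In a functional assay on C6 cells (Rattus norvegicus) for cytotoxicity, read by MTT assay, with a stated time of 24 h, tested at 50 ug/mL (a lower number here means a stronger effect, a higher number a weaker effect of the compound at the concentration tested), compound 3 stands second highest of the three numbers, nearest compound 1 and furthest from compound 2, both within the scatter. Compound 4, `Cc1ccc(-c2cs/c(=N/NC(=O)CSc3nnc(C)s3)n2-c2ccccc2)cc1`, differs from compound 3 by 5-methyl-1,3,4-thiadiazol-2-yl in place of 1-methyl-1H-tetrazol-5-yl on a sulfur. For the measured compounds named here, the one measured step on the same sulfur, a number 9.5 percentage points lower from compound 2 to compound 3 (within the scatter), stayed within the scatter. Compound 1 already carries the 5-methyl-1,3,4-thiadiazol-2-yl group on a sulfur, though on a different core, and gives a number close to that of compound 3. The step of a number 3.3 percentage points lower from compound 3 to compound 4 (within the scatter) is therefore expected to stay within the scatter. Compound 4 is estimated at 41%, in a range from 29% to 53%.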

Compound 4, a percentage reported as activity, at one concentration (the size of the read-out at that concentration, not a potency): 40.6%
Compound 4: middle estimate off by 0.4 percentage points, on the high side, within the range that was stated.
By their numbers in this assay, from the lowest: compounds 1, 4, 3 and 2 (each within the scatter of the next, the first and the last beyond it).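

In this assay, for the compounds shown here, the 5-methyl-1,3,4-thiadiazol-2-yl group on a sulfur gives a number 3.7 percentage points lower from compound 3 to compound 4 (within the scatter) when it replaces 1-methyl-1H-tetrazol-5-yl, while replacing 4-methyl-4H-1,2,4-triazol-3-yl gives a number 13.2 percentage points lower from compound 2 to compound 4 (beyond the scatter) and is the only step at this position beyond the scatter. With that group held constant, methyl in place of fluoro on an aromatic carbon gives a number 3.2 percentage points higher from compound 1 to compound 4 (within the scatter) as the step. No evidence is available on what lies behind these steps. Still open, as far as these compounds go, is how a saturated chain or an amine on this sulfur, in place of the five-membered aromatic ring, would read in this assay.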